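The source may hold more compounds than are shown below. What is called first, only, known or untested is meant among the compounds shown, and "the series" means these compounds.

In a functional assay on the whole organism for inhibition, with Cavia porcellus as the target (a higher number here means that more compound is needed for the effect, a lower number that less compound is needed), compound 2 `COc1ccccc1OCC1SCCN1C(C)=O` gives 46 mg/kg, a value within the usual scatter of both compound 1 `COc1ccc(OCC2SCCN2C(=O)Cn2ccnc2)cc1` at 48 mg/kg and compound 3 `COc1ccccc1OCC1SCCN1C(=O)C(C)(C)C(=O)O` at 34 mg/kg, so it is not set apart from either. Compound 4 `COc1ccccc1OCC1SCCN1C(=O)CC(=O)N1CCN(C)CC1` keeps the core of compound 2 and places (4-methylpiperazin-1-yl)carbonyl in place of hydrogen on a saturated chain carbon bound to a carbonyl carbon. One measured step also alters the group on that carbonyl carbon, namely a 1.4-fold lower number from compound 2 to compound 3 (0.13 log units; within the scatter), where 1-carboxy-1-methylethyl replaces methyl. For the measured compounds named here, this single step is thin evidence, and no measured compound carries the new group. The expected change is therefore none beyond the scatter, an estimated 1.2-fold lower number from compound 2 to compound 4 (0.06 log units; within the scatter) in this assay. The estimated value for compound 4 is 40 mg/kg, with an expected range of 20 mg/kg to 80 mg/kg as the outcome.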

Compound 4, dose for half-maximal effect: 27 mg/kg
Compound 4: middle estimate off by 1.5-fold (0.17 log units), on the high side, and the stated range covers the measured number.
By their numbers in this assay, from the lowest: compounds 4, 3, 2 and 1 (each within the scatter of the next).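

In this assay, this saturated chain carbon bound to a carbonyl carbon now carries (4-methylpiperazin-1-yl)carbonyl, a group of 9 heavy atoms with a six-membered non-aromatic ring, and the result is a 1.7-fold lower number from compound 2 to compound 4 (0.23 log units; within the scatter). Even this addition, a kind of group absent from the earlier compounds, leaves the number within the scatter. No measurement is available that could explain the step. Open, going by these compounds, is whether a plain amine or a longer chain on this same carbon would move the number beyond the scatter, in either direction.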